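The source may report more compounds than this note shows. Statements on the series, on what has been measured and on what is new or still open speak of the compounds shown alone.

Compound 1, `Cn1nc(C(C)(C)C)cc1NC(=O)Nc1cc(F)cc(F)c1`, gives 1.1 degrees C in an assay on isolated protein for inhibition of serine/threonine-protein kinase 10 (Homo sapiens), read by thermal shift assay, tested at 10 uM; a higher number here means that the compound stabilises the target more against heat, a lower number that the compound stabilises the target less.
Compound 2, `CC(C)(C)c1cc(NC(=O)Nc2cc(F)cc(F)c2)n(-c2ccc(F)cc2)n1`, gives 1.7 degrees C in this assay.

Only these two compounds have been measured, and they cannot be told apart: the step of a number 0.60 degrees C higher from compound 1 to compound 2 (within the scatter) stays within the scatter of the method. That step exchanges the group on the aromatic nitrogen of the shared core and leaves the tert-butyl group untouched.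

Compound 3, `Cn1nc(-c2ccccc2)cc1NC(=O)Nc1cc(F)cc(F)c1`, is not yet measured. It differs from compound 1 in one place: phenyl in place of tert-butyl on an aromatic carbon. Within the data shown here, no measured step touches this position, so nothing in the data bears directly on it; the single step known, from compound 1 to compound 2, concerns another part of the core and was itself within the scatter. With no step beyond the scatter anywhere in the set, the expectation for this assay is a step of no more than the scatter in either direction, worded as a number 0.20 degrees C higher from compound 1 to compound 3 (within the scatter). Compound 3 is therefore estimated at 1.3 degrees C, with a range from 0 degrees C to 2.6 degrees C.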

Compound 3, shift of the target's melting temperature: -0.7 degrees C
The estimate for compound 3 lay 2.0 degrees C above the measured number; measured number outside the range, below it.
By their numbers in this assay, from the lowest: compound 3; then compounds 1 and 2 (each within the scatter of the next).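

In this assay, among these compounds, this position responds where the aromatic nitrogen did not: the exchange here gives a number 1.8 degrees C lower from compound 1 to compound 3 (beyond the scatter) and is the only step so far beyond the scatter, whereas the change on the nitrogen gave a number 0.60 degrees C higher from compound 1 to compound 2 (within the scatter) and stayed within it. Among the compounds shown here, the response comes from an exchange of one carbon-only group for another, with tert-butyl (4 heavy atoms, no ring) leaving and phenyl (6 heavy atoms, one six-membered aromatic ring) entering, neither carrying a hydrogen-bond donor or acceptor and neither a net charge; compound 3, at -0.7 degrees C, is also the only one of the three compounds with a number below zero. Nothing available explains why the number falls with this exchange.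

The compounds shown leave open whether the fall belongs to phenyl alone or would also appear with other groups at this aromatic carbon, such as cyclopropyl, isopropyl, a methoxy group or an amine. They also leave open whether phenyl in place of tert-butyl would give a similar step when the aromatic nitrogen carries the 4-fluorophenyl group of compound 2.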